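This account rests on a few compounds, and the source may have more. Where it says the series, first, only, none or still open, it means among the compounds named here.

Compound 1 `CCC(=O)N1CCc2nc(C#Cc3ccccc3)sc2C1` gives 38 nM in an assay on HEK293 cells for negative allosteric modulation of metabotropic glutamate receptor 5 (Homo sapiens), read by FLIPR, with a stated time of 1 h; a lower number here means a stronger inhibitor, a higher number a weaker inhibitor. Compound 2 `O=C(C1CCC1)N1CCc2nc(C#Cc3ccccc3)sc2C1` gives 370 nM in this assay, a step of a 9.7-fold higher number from compound 1 to compound 2 (0.99 log units; beyond the scatter). Compound 3 `O=C(C1CCCC1)N1CCc2nc(C#Cc3ccccc3)sc2C1` stands apart: in this assay compound 3 gives > 10000 nM, which is a limit of the assay and not a number. This is the limit noted as the limit of > 10000 nM in this assay, at which 1 of the 3 values shown sits. The steps of an at least 260-fold higher number from compound 1 to compound 3 (2.42 log units; beyond the scatter) and an at least 27-fold higher number from compound 2 to compound 3 (1.43 log units; beyond the scatter) run the same way. Compound 4 `CC1CCCC(C(=O)N2CCc3nc(C#Cc4ccccc4)sc3C2)C1` brings (3-methylcyclohexyl in place of cyclopentyl on a carbonyl carbon). The measured steps bear on this: each enlargement of the group on the carbonyl carbon, from ethyl to cyclobutyl to cyclopentyl, gave a higher number, and compound 4 carries the largest group of the four. Compound 4 is therefore expected to show a step that the limit leaves unreadable from compound 3 to compound 4 in this assay. Compound 4 is estimated at 25000 nM, between 8000 nM and 100000 nM.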

Compound 4, half-maximal inhibitory concentration: > 10000 nM
Compound 4: only a limit was reported; the forecaster's own chance of this, stated with the estimate: 85%; the middle value is on the limit's open side.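

In this assay compound 4 gives > 10000 nM as a limit of the assay and not a number, so 3-methylcyclohexyl on this carbonyl carbon joins cyclopentyl at that limit: the limit of > 10000 nM in this assay, at which 2 of the 4 values shown sit. Against the smaller groups the result reads as an at least 27-fold higher number from compound 2 to compound 4 (1.43 log units; beyond the scatter) and an at least 260-fold higher number from compound 1 to compound 4 (2.42 log units; beyond the scatter). The step from compound 3 to compound 4 cannot be read. The larger, methyl-bearing ring thus brought back no measurable inhibition at this position.

On these data alone, how far compound 3 and compound 4 lie past the limit remains open. Also open, as far as these compounds go, is how a methyl group, a tetrahydropyranyl ring or an amine would behave on this carbonyl carbon.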